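A few compounds are considered here, and "the series" means these few. Any claim that something is new, unique, unknown or untested is made for them only; others in the source may bear on it.

In an in vitro ADME assay on microsomes from liver (Mus musculus) for pharmacokinetics, read by LC-MS, with a stated time of 10 min, tested at 1 uM (a higher number here means faster removal of the compound, a lower number slower removal), compound 1 `Cc1ccc(NC(=O)[C@H]2CN(C)C[C@@H]2c2ccc(/C=C/C(=O)Nc3ccccc3N)cc2)cc1` gives 62 mL/min/kg, compound 2 `CN1C[C@H](C(=O)Nc2ccc(C#N)cc2)[C@@H](c2ccc(/C=C/C(=O)Nc3ccccc3N)cc2)C1` gives 35 mL/min/kg and compound 3 `CC(C)c1ccc(NC(=O)[C@H]2CN(C)C[C@@H]2c2ccc(/C=C/C(=O)Nc3ccccc3N)cc2)cc1` gives 54 mL/min/kg. Compound 3 stands within the scatter of both other compounds: a 1.1-fold lower number from compound 1 to compound 3 (0.06 log units; within the scatter) and a 1.5-fold higher number from compound 2 to compound 3 (0.19 log units; within the scatter).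

Compound 4 `CN1C[C@H](C(=O)Nc2ccc(C3CC3)cc2)[C@@H](c2ccc(/C=C/C(=O)Nc3ccccc3N)cc2)C1` follows from compound 3 by cyclopropyl in place of isopropyl on an aromatic carbon. Among the measured compounds shown here, the same position has so far given a 1.8-fold lower number from compound 1 to compound 2 (0.25 log units; within the scatter) for cyano in place of methyl, and no measured step there leaves the scatter. For the measured compounds named here, no measured compound carries cyclopropyl, so the evidence is indirect. No step beyond the scatter is expected in this assay. The estimated step is a 1.1-fold lower number from compound 3 to compound 4 (0.03 log units; within the scatter). For compound 4 the expected value is 50 mL/min/kg, with an estimated range of 28 mL/min/kg to 85 mL/min/kg.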

Compound 4, clearance: 60 mL/min/kg
For compound 4 the middle estimate is 1.2-fold (0.08 log units) below the measured one; the range from low to high includes it.
By their numbers in this assay, from the lowest: compounds 2, 3, 4 and 1 (each within the scatter of the next).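

In this assay, among the compounds shown here, cyclopropyl, the first group here to bring a ring, stays within the scatter of isopropyl (a 1.1-fold higher number from compound 3 to compound 4 (0.05 log units; within the scatter)), of cyano (a 1.7-fold higher number from compound 2 to compound 4 (0.23 log units; within the scatter)) and of methyl (a 1.0-fold lower number from compound 1 to compound 4 (0.01 log units; within the scatter)). Across these four groups on the aromatic carbon, para to a large group, no step yet leaves the scatter. Nothing available bears on a cause for these values.

Open, as far as these compounds go, is whether an amine, a carboxylic acid or a longer chain at this position would give a step beyond the scatter. The shared core stays fixed throughout, leaving changes elsewhere untested in these compounds.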